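A few compounds are considered here, and "the series" means these few. Any claim that something is new, unique, unknown or untested is made for them only; others in the source may bear on it.

Working notes on the series. In a physicochemical assay for lipophilicity, read by HPLC, measured as chromatographic lipophilicity, at pH 7.4 (a lower number here means a more polar compound, a higher number a more lipophilic compound), compound 1 `O=C(c1cnco1)N1CCC(C(=O)N2N=CC[C@H]2c2ccccc2)CC1` gives 2.7 and compound 2 `CC(=O)N1CCC(C(=O)N2N=CC[C@H]2c2ccccc2)CC1` gives 2.5. These two numbers lie within the usual scatter of each other, so compound 2 has no separate place on the scale yet.

Next comes compound 3 `O=C(C1CCN(c2ccccn2)CC1)N1N=CC[C@H]1c1ccccc1`, with pyridin-2-yl in place of acetyl on an amine nitrogen in a ring. Among the measured compounds shown here, only one measured step bears on this change: a number 0.20 log units lower from compound 1 to compound 2 (within the scatter). There, methyl takes the place of 1,3-oxazol-5-yl on a carbonyl carbon. That step keeps the carbonyl, whereas the new change removes it, so the step is only a weak guide. For the measured compounds named here, no measured pair covers a change of this kind, and the expectation rests on judgement with a wide range. In this assay, a rise beyond the scatter is expected. The expected step is a number 1.10 log units higher from compound 2 to compound 3 (beyond the scatter). For compound 3 the estimated value is 3.6, with an expected range from 3.1 to 4.1.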

Compound 3, distribution coefficient: 5.1
Beside the measured number, compound 3's estimate is 1.50 log units below it; measured number outside the range, above it.
By their numbers in this assay, from the lowest: compounds 2 and 1 (each within the scatter of the next); then compound 3.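

In this assay the group on the amine nitrogen in the six-membered non-aromatic ring can move the number far: pyridin-2-yl in place of acetyl gives a number 2.60 log units higher from compound 2 to compound 3 (beyond the scatter) and pyridin-2-yl in place of (1,3-oxazol-5-yl)carbonyl gives a number 2.40 log units higher from compound 1 to compound 3 (beyond the scatter) on the same nitrogen. The earlier pair kept the carbonyl at this place and stayed within the scatter, while both new steps lose that carbonyl and bring in an aromatic ring, and both lie beyond the scatter at a similar size. Nothing measured in the series accounts for the size of this rise.

The compounds shown do not separate the loss of the carbonyl from the entry of pyridin-2-yl, since the two happen together in both new steps. A plain methyl or a phenyl on this nitrogen would help to tell these apart, and a pyridin-2-yl carrying a carboxylic acid or an amine would show how far the number at this position can be brought back down.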